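The source may report more compounds than this note shows. Statements on the series, on what has been measured and on what is new or still open speak of the compounds shown alone.

Series notes. Compound 1, `CCC(C(=O)N1CCN(c2ccccc2)CC1)N1C(=O)CCC1=O`, gives 75% in a functional assay on the whole organism (strain Swiss) with Mus musculus as the target, in the maximal electroshock model, with a stated time of 0.25 h, at a dose of 300 mg/kg by the intraperitoneal route; a lower number here means a weaker effect, a higher number a stronger effect of the compound at the dose given. Compound 2, `CCC(C(=O)N1CCN(c2cccc(C(F)(F)F)c2)CC1)N1C(=O)CCC1=O`, carries trifluoromethyl in place of hydrogen on an aromatic carbon and gives 75%; the step of no change at the digits printed from compound 1 to compound 2 (within the scatter) is within the scatter. Compound 3, `CC(C(=O)N1CCN(c2ccccc2)CC1)N1C(=O)CCC1=O`, has hydrogen in place of methyl on a saturated chain carbon, two bonds along the chain from an amide-type nitrogen in a ring and a carbonyl carbon, and gives 100%; the step of a number 25 percentage points higher from compound 1 to compound 3 (beyond the scatter) lies beyond the scatter and is modest. Among the three numbers compound 1 stands level with compound 2, the two together the lowest; its furthest neighbour is compound 3.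

Compound 4, `CCC(C(=O)N1CCN(c2ccc(F)cc2)CC1)N1C(=O)CCC1=O`, differs from compound 1 by fluoro in place of hydrogen on an aromatic carbon. Going by the values given here, the only step that bears on this change is the aromatic substitution from compound 1 to compound 2, which left this assay unchanged within the scatter; the change on the saturated chain in compound 3 touches a different part of the molecule and does not bear on it. Because no change at the digits printed from compound 1 to compound 2 (within the scatter) showed no change, no step beyond the scatter is expected here: the expected step is no change at the digits printed from compound 1 to compound 4 (within the scatter). For compound 4 the estimate is 75%, with a range from 50% to 100%.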

Compound 4, a percentage reported as activity, at one dose (the size of the read-out at that dose, not a potency): 0%
Compound 4: middle estimate off by 75 percentage points, on the high side; measured number outside the range, below it.
By their numbers in this assay, from the lowest: compound 4; then compounds 1 and 2 (each within the scatter of the next); then compound 3.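

In this assay the six-membered aromatic ring of the core does not accept every substitution without effect: fluoro in place of hydrogen, para to a large group, gives a number 75 percentage points lower from compound 1 to compound 4 (beyond the scatter), whereas the trifluoromethyl change gave no change at the digits printed from compound 1 to compound 2 (within the scatter). The silence of that earlier change therefore does not carry over to this one, and the phenyl to 4-fluorophenyl change alone, a single added fluorine atom, is enough to produce a large step at this dose. Nothing measured on these compounds accounts for the drop.

Still open, from the compounds shown here alone, is whether the drop belongs to fluoro itself or to any substituent at this position, a question that chloro, methyl or methoxy on the same carbon would address. Also open, going by these compounds, is whether the same change carries over to the shared core with hydrogen in place of methyl on the chain, as in compound 3, and whether a read-out at other doses or times would show the same step.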